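A few compounds are considered here, and "the series" means these few. Any claim that something is new, unique, unknown or untested is made for them only; others in the source may bear on it.

Measured in an ADME assay on Akata cells (Homo sapiens) for cytotoxicity, with a stated time of 7 days; on this read-out lower numbers stand for higher toxicity in this test and higher numbers for lower toxicity in this test:
compound 1 `CCCCCOc1nc(N)nc2c1ncn2/C=C1/CC1(CO)CO` — > 20000 nM, a limit
compound 2 `Nc1nc(OCc2ccccc2)c2ncn(/C=C3/CC3(CO)CO)c2n1` — > 20000 nM, a limit
compound 3 `CC(C)Nc1nc(N)nc2c1ncn2/C=C1/CC1(CO)CO` — > 24000 nM, a limit

Compound 3 stands only at a limit of this assay, not at a number. Among the measured compounds shown here, the whole set sits at limits, the limit of > 20000 nM in this assay, at which 2 of the 3 values shown sit, and (the limit of > 24000 nM in this assay, at which 1 of the 3 values shown sits), so no compound can be placed above another. The steps that end at compound 3, a step that the two limits leave unreadable from compound 1 to compound 3 and a step that the two limits leave unreadable from compound 2 to compound 3, are therefore unreadable in size and direction.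

Compound 4 `CCCCOc1nc(N)nc2c1ncn2/C=C1/CC1(CO)CO` differs from compound 3 by butoxy in place of isopropylamino on an aromatic carbon. The comparable steps give no readable size, so no step beyond the scatter is expected, and compound 4 is most likely to sit at a limit again. Compound 4 is estimated at 25000 nM, range 15000 nM to 60000 nM, which means an expected step that the limit leaves unreadable from compound 3 to compound 4.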

Compound 4, half-maximal cytotoxic concentration: > 20000 nM
Compound 4: a limit, no number (the forecaster's own chance of this, stated with the estimate: 85%); the middle value is on the limit's open side.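

In this assay compound 4 gives > 20000 nM, a limit, so the steps to it from compound 1, compound 2 and compound 3 cannot be read. From the compounds shown here alone, whether any of these four compounds differs from another in cytotoxicity remains open.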